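A para-chloro added to the phenyl of compound 2

This account rests on a few compounds, and the source may have more. Where it says the series, first, only, none or still open, it means among the compounds named here.

Measured so far:
compound 1 `O=C(Nc1ccc(Oc2ccnc3[nH]ccc23)cc1)c1cn(-c2ccc(F)cc2)c2ccccc2c1=O`: 390 nM
compound 2 `Cn1ccc2c(Oc3ccc(NC(=O)c4cn(-c5ccccc5)c5ccccc5c4=O)cc3F)ccnc21`: 1720 nM

In a functional assay on A549 cells (Homo sapiens) for inhibition, read by MTT assay, with a stated time of 72 h (on this read-out lower numbers stand for stronger inhibition and higher numbers for weaker inhibition), compound 2 gives 1720 nM, the highest of the two numbers, while compound 1 gives 390 nM, a gap beyond the usual scatter. Compound 3 `Cn1ccc2c(Oc3ccc(NC(=O)c4cn(-c5ccc(Cl)cc5)c5ccccc5c4=O)cc3F)ccnc21` differs from compound 2 by chloro in place of hydrogen on an aromatic carbon. For the measured compounds named here, no step between measured compounds isolates this change, so the expected effect is uncertain; in this assay a modest lowering of the number, close to the edge of the scatter, is expected for compound 3, namely a 2.2-fold lower number from compound 2 to compound 3 (0.33 log units; beyond the scatter). Compound 3 is thus estimated at 800 nM, within 300 nM to 2500 nM.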

Compound 3, half-maximal inhibitory concentration: 250 nM
Beside the measured number, compound 3's estimate is 3.2-fold (0.51 log units) above it, and the stated range ends above it.
By their numbers in this assay, from the lowest: compounds 3 and 1 (each within the scatter of the next); then compound 2.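

In this assay the change from phenyl to 4-chlorophenyl gives a 6.9-fold lower number from compound 2 to compound 3 (0.84 log units; beyond the scatter) and shows that this place on the ring, para to a large group, responds to one added heavy atom. For the compounds shown here, compounds 1 and 2 differ in more than one place, so this is the first single change that can be read on its own. Nothing available explains why the number falls.

From the compounds shown here alone, whether a methoxy group, an amine or a carboxylic acid at this same place would also lower the number remains open.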